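From 3-chlorobenzyl to benzyl

The source may report more compounds than this note shows. Statements on the series, on what has been measured and on what is new or still open speak of the compounds shown alone.

Compound 1 (`Fc1cccc(F)c1CSc1nnc(-c2cnccn2)s1`): 29200 nM
Compound 2 (`Clc1cccc(CSc2nnc(-c3cnccn3)n2-c2ccccc2)c1`): 13500 nM

In a functional assay on HeLa cells (Homo sapiens) for antiproliferative activity, read by MTT assay, with a stated time of 48 h (a higher number here means a weaker inhibitor, a lower number a stronger inhibitor), two compounds have been measured so far. Compound 2 holds the lower of the two numbers, and the gap to compound 1 lies beyond the scatter. Compound 3 (`c1ccc(CSc2nnc(-c3cnccn3)n2-c2ccccc2)cc1`) has yet to be measured. It departs from compound 2 in one place, with hydrogen in place of chloro on an aromatic carbon, meta to a large group (hydrogen in place of chloro on an aromatic carbon), so that 3-chlorobenzyl becomes benzyl.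

Among the measured compounds shown here, no measured pair differs in one place only, so the data do not show directly what this exchange does. Compound 1 and compound 2 differ in more than one place and give no clean guide. The expectation therefore stays close to compound 2 (13500 nM), with a modest move toward a higher number in this assay that may not clear the scatter by much. The expected change is small (a 1.4-fold higher number from compound 2 to compound 3 (0.15 log units; within the scatter)). Compound 3 is estimated at 19000 nM, with an expected range from 8000 nM to 45000 nM.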

Compound 3, half-maximal inhibitory concentration: 35600 nM
For compound 3 the middle estimate is 1.9-fold (0.27 log units) below the measured one, within the range that was stated.
By their numbers in this assay, from the lowest: compound 2; then compounds 1 and 3 (each within the scatter of the next).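

In this assay, among the compounds shown here, the exchange of 3-chlorobenzyl for benzyl gives the first direct reading at this position: a 2.6-fold higher number from compound 2 to compound 3 (0.42 log units; beyond the scatter) is a modest step, but it lies beyond the scatter. Losing the chloro from this aromatic carbon, meta to a large group, therefore weakens the compound on this core, which compound 1 and compound 2 could not show, as they differ in more than one place. No measurement given here bears on what lies behind this shift.

The compounds shown leave open whether another group on the same aromatic carbon, such as bromo or methoxy, would match the chloro of compound 2 or improve on it, and whether an amine or a carboxylic acid would be tolerated there. They also leave open whether the exchange of chloro for hydrogen would have a similar effect on a different core, as this reading rests on a single pair of compounds in one cell assay.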